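The source may report more compounds than this note shows. Statements on the series, on what has been measured and on what is new or still open speak of the compounds shown alone.

Compound 1 `CC(=O)N1N=C(c2ccc3ccccc3c2)OC1c1cccc(Br)c1` gives 2.34 ug/mL
Compound 2 `CC(=O)N1N=C(c2ccc3ccccc3c2)OC1c1ccc(Cl)cc1` gives 2.63 ug/mL
Compound 3 `CC(=O)N1N=C(c2ccc3ccccc3c2)OC1c1cccnc1` gives 2.61 ug/mL

All three values come from a functional assay on MCF7 cells (Homo sapiens) for antiproliferative activity, read by MTT assay, with a stated time of 48 h (a higher number here means a weaker inhibitor, a lower number a stronger inhibitor), and the compounds differ only in the group on a saturated ring carbon of the shared core. Compound 3 cannot be separated from the other two, since the steps are a 1.1-fold higher number from compound 1 to compound 3 (0.05 log units; within the scatter) and a 1.0-fold lower number from compound 2 to compound 3 (0.00 log units; within the scatter) with both inside the normal spread of repeat measurements. The next compound is compound 4 `CC(=O)N1N=C(c2ccc3ccccc3c2)OC1c1ccsc1` which carries thiophen-3-yl in place of pyridin-3-yl on a saturated ring carbon and keeps the shared core. The measured swaps at that same carbon bear on this change, and the remaining one is a 1.1-fold higher number from compound 1 to compound 2 (0.05 log units; within the scatter) so none of them goes beyond the scatter. Among the measured compounds shown here, no compound with a five-membered aromatic ring at this carbon has been measured yet, which leaves real uncertainty. In this assay no step beyond the scatter is therefore expected, and the estimated change is a 1.0-fold lower number from compound 3 to compound 4 (0.00 log units; within the scatter) in size. For compound 4 the estimate is 2.6 ug/mL with 1.6 ug/mL to 4.2 ug/mL as the expected range.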

Compound 4, half-maximal inhibitory concentration: 7.98 ug/mL
The estimate for compound 4 lay 3.1-fold (0.49 log units) below the measured number; measured number above the stated range.
By their numbers in this assay, from the lowest: compounds 1, 3 and 2 (each within the scatter of the next); then compound 4.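

Among the compounds shown here, until now, 3-bromophenyl, 4-chlorophenyl and pyridin-3-yl on this saturated ring carbon could not be told apart, so the position looked tolerant; thiophen-3-yl is the first group to change the number in this assay, giving a weaker inhibitor (a 3.1-fold higher number from compound 3 to compound 4 (0.49 log units; beyond the scatter)). The same holds against the other two groups (a 3.0-fold higher number from compound 2 to compound 4 (0.48 log units; beyond the scatter)) (a 3.4-fold higher number from compound 1 to compound 4 (0.53 log units; beyond the scatter)), so this carbon does respond to what it carries, though modestly. Nothing measured here explains the loss.

For the compounds shown here, compound 4 is the only compound with a five-membered aromatic ring and the only one with sulfur, so these two changes cannot be separated. A furan-3-yl group, a five-membered aromatic ring with oxygen in place of sulfur, would help to tell them apart.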